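The compounds below may be only part of what the source reports. "The series", "measured", "known", "first", "only" and "open" are said of these compounds alone.

Measured so far in a functional assay on Huh-7 cells (Homo sapiens) for inhibition, read by MTT assay, with a stated time of 48 h; a lower number here means a stronger inhibitor, a higher number a weaker inhibitor:
- compound 1 `COc1ccc2c(=O)c(/C=C/C(=O)Nc3cccc(Cl)c3)coc2c1`, which gives only a limit, > 100000 nM
- compound 2 `COc1ccc(CNC(=O)/C=C/c2coc3cc(O)ccc3c2=O)cc1`, which gives 8430 nM
- compound 3 `COc1ccc2c(=O)c(/C=C/C(=O)NCc3cccc(F)c3)coc2c1`, which gives 10100 nM

Compound 3 stands highest of the two numbers. Its nearest neighbour is compound 2, and the gap between them lies within the usual scatter, so no order can be read from those two. Among the compounds with values here, the one remaining value is a limit of the assay rather than a number.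

Compound 4 `CCOc1ccc(NC(=O)/C=C/c2coc3cc(OC)ccc3c2=O)cc1` has not yet been measured. It differs from compound 3 in one place: 4-ethoxyphenyl in place of 3-fluorobenzyl on an amide-type nitrogen. Within the data shown here, one measured step bears on this change. The step of an at least 9.9-fold lower number from compound 1 to compound 3 (0.99 log units; beyond the scatter) ran from a limit to a number when a benzyl-type group replaced a phenyl-type group on the amide-type nitrogen, and that step rests on (the limit of > 100000 nM in this assay, at which 1 of the 3 values shown sits). Compound 4 again carries a phenyl-type group on the amide-type nitrogen, which is the reverse kind of change. The expected step of a 5.9-fold higher number from compound 3 to compound 4 (0.77 log units; beyond the scatter) is therefore towards a higher number, beyond the scatter, with a real chance that only a limit is reported. For compound 4 the estimate in this assay is 60000 nM, with a range from 20000 nM to 200000 nM.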

Compound 4, half-maximal inhibitory concentration: 3230 nM
For compound 4 the middle estimate is 19-fold (1.27 log units) above the measured one; the whole stated range lies above it.
By their numbers in this assay, from the lowest: compound 4; then compounds 2 and 3 (each within the scatter of the next). At a limit, above all of these: compound 1.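

The earlier step suggested that a phenyl-type group on the amide-type nitrogen fares worse than a benzyl-type group, but in this assay the new result points the other way, with a 3.1-fold lower number from compound 3 to compound 4 (0.50 log units; beyond the scatter) when 4-ethoxyphenyl takes the place of 3-fluorobenzyl. The choice between the two group types therefore does not settle the result alone, as two phenyl-type groups at this nitrogen also differ sharply, with an at least 30-fold lower number from compound 1 to compound 4 (1.49 log units; beyond the scatter) when 4-ethoxyphenyl takes the place of 3-chlorophenyl. Compound 1 gives only a limit, so this second step has a lower bound on its size and no exact size: the limit of > 100000 nM in this assay, at which 1 of the 4 values shown sits.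

The 3-chlorophenyl and 4-ethoxyphenyl groups differ both in what the ring carries and in where their names place it, so a 4-chlorophenyl or 3-ethoxyphenyl group would be needed to tell these two changes apart. Going by these compounds, it also remains open how a 4-ethoxybenzyl group would compare on the same nitrogen, and whether a 4-aminophenyl group or a longer chain such as 4-butoxyphenyl would keep the lower number.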